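Fluoro to Trifluoromethyl Swap Across Two Cores

A few compounds are considered here, and "the series" means these few. Any claim that something is new, unique, unknown or untested is made for them only; others in the source may bear on it.

Measured compounds:
compound 1 `CC(=O)Nc1ccc(O)c(C(=O)/C=C/c2cccc(F)c2)c1`: 30100 nM
compound 2 `CC(=O)Nc1ccc(O)c(C(=O)/C=C/c2cccc(C(F)(F)F)c2)c1`: 32100 nM
compound 3 `CC(=O)Nc1ccc2oc(-c3ccc(F)cc3)c(O)c(=O)c2c1`: 34100 nM

All three were run in an ADME assay on MT4 cells (Homo sapiens) for cytotoxicity, read by MTT assay, with a stated time of 4 days; a lower number here means that less compound is tolerated, a higher number that more compound is tolerated. Compound 1 and compound 2 share one core and differ by trifluoromethyl in place of fluoro on an aromatic carbon. The step is a 1.1-fold higher number from compound 1 to compound 2 (0.03 log units; within the scatter). Compound 3 has a different core; the difference between the two cores is not broken down here, and the two values lie within the scatter of each other.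

Compound 4 `CC(=O)Nc1ccc2oc(-c3ccc(C(F)(F)F)cc3)c(O)c(=O)c2c1` carries the same kind of change on the core of compound 3: trifluoromethyl in place of fluoro on an aromatic carbon. The place differs in one respect: in compound 2 the group sits meta to a large group, in compound 4 para to a large group, so the change is of the same kind, not the same.

Given that the change made only a 1.1-fold higher number from compound 1 to compound 2 (0.03 log units; within the scatter), a step of similar size is expected here, a 1.1-fold higher number from compound 3 to compound 4 (0.02 log units; within the scatter), with the wider range reflecting the different core and place. Compound 4 is thus estimated at 36000 nM, between 18000 nM and 72000 nM.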

Compound 4, half-maximal cytotoxic concentration: 7300 nM
Beside the measured number, compound 4's estimate is 4.9-fold (0.69 log units) above it, and the stated range ends above it.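

In this assay, trifluoromethyl in place of fluoro on an aromatic carbon gives a 4.7-fold lower number from compound 3 to compound 4 (0.67 log units; beyond the scatter). The outcome of this change therefore does not carry over unchanged from the core of compound 1 to the core of compound 3: the same change on two cores in this assay, a 1.1-fold higher number (0.03 log units; within the scatter) from compound 1 to compound 2 and a 4.7-fold lower number (0.67 log units; beyond the scatter) from compound 3 to compound 4, 5.0-fold (0.70 log units) apart, beyond the scatter of two such steps

This does not show that the core alone accounts for the gap: in compound 4 the group sits para to a large group, unlike in compound 2, and a single pair on each core cannot separate core from place.

Left open is how the core of compound 3 responds with trifluoromethyl in the place it holds in compound 2, and how the core of compound 1 responds with it para to a large group. Also open, from the compounds shown here alone, is whether other groups in that place, such as chlorine, a methoxy group, an amine or a carboxylic acid, would follow compound 2 or compound 4 in this assay.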